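The source may hold more compounds than are shown below. What is called first, only, known or untested is meant among the compounds shown, and "the series" means these compounds.

In an assay on HEK-293T cells for inhibition of diacylglycerol lipase-alpha (Homo sapiens), read by colorimetric assay (on this read-out lower numbers stand for stronger inhibition and higher numbers for weaker inhibition), two compounds of the shared core have been measured. Compound 1 `O=C(CCCc1ccccc1)c1nc2ncccc2o1` gives 2240 nM there. Compound 2 `CC(=O)c1nc2ncccc2o1` returns only the limit of the assay, > 10000 nM in this assay. For the measured compounds named here, this is the one value at the limit of > 10000 nM in this assay, at which 1 of the 2 values shown sits, so compound 2 stands without a number of its own. Compound 3 `CCCCCCCC(=O)c1nc2ncccc2o1` has not yet been measured in this assay. It differs from compound 2 by hexyl in place of hydrogen on a saturated chain carbon bound to a carbonyl carbon. Going by the values given here, no step between measured compounds that differ in one place is at hand, so the size of the change can only be judged from the two values shown. Compound 1, which carries a chain of its own, reaches 2240 nM in this assay. Compound 2, without such a chain, stays at the limit. On that comparison a chain of the hexyl kind is expected to bring a measurable value, and the change is expected to come out as an at least 3.3-fold lower number from compound 2 to compound 3 (0.52 log units; beyond the scatter) in this assay, towards stronger inhibition and beyond the scatter, though the limit on compound 2 leaves its exact size open. Compound 3 is estimated at 3000 nM, with a range from 800 nM to 10000 nM.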

Compound 3, half-maximal inhibitory concentration: 631 nM
Estimate against measurement, compound 3: 4.8-fold (0.68 log units) above; the whole stated range lies above it.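

In this assay, hexyl in place of hydrogen on a saturated chain carbon bound to a carbonyl carbon moves the series clearly towards stronger inhibition, and the step reads an at least 15-fold lower number from compound 2 to compound 3 (1.19 log units; beyond the scatter). That step has a floor and no exact size, as compound 2 has a limit of the assay and no number of its own: the limit of > 10000 nM in this assay, at which 1 of the 3 values shown sits. The chain's end also matters at this position, since butyl in place of phenyl on a saturated chain carbon, three bonds along the chain from a carbonyl carbon, gives a 3.5-fold lower number from compound 1 to compound 3 (0.55 log units; beyond the scatter), so the plain alkyl chain of compound 3 outdoes the phenyl-ended chain of compound 1, a comparison that compound 2 alone could not offer.

As far as these compounds go, with only these three compounds at this position, it remains open whether a longer chain, such as octyl or decyl, would lower the number further or reverse the gain. From the compounds shown here alone, it is equally open whether a chain ending in an amine or a carboxylic acid would keep the gain seen with hexyl.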